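This account rests on a few compounds, and the source may have more. Where it says the series, first, only, none or still open, it means among the compounds named here.

In a functional assay on MDA-MB-231 cells (Homo sapiens) for inhibition, read by MTT assay, with a stated time of 48 h (a higher number here means a weaker inhibitor, a lower number a stronger inhibitor), compound 1 `CCc1ccc(-c2nc3ccccn3c2Sc2ccccc2)cc1` gives only a limit, > 100000 nM, and not a number. Within the data shown here, compound 2 `C(=C/c1nc2ccccn2c1Sc1ccccc1)\c1ccccc1` gives 25300 nM, the only true number so far. Its standing can be judged only against compound 1. Among the measured compounds shown here, the one measured step is an at least 3.9-fold lower number from compound 1 to compound 2 (0.59 log units; beyond the scatter), with 2-phenylethenyl in place of 4-ethylphenyl on an aromatic carbon. Its size is a bound and not an exact figure, as it rests on (the limit of > 100000 nM in this assay, at which 1 of the 2 values shown sits).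

Compound 3 `CSc1ccc(-c2nc3ccccn3c2Sc2ccccc2)cc1` differs from compound 2 as follows: 4-(methylsulfanyl)phenyl in place of 2-phenylethenyl on an aromatic carbon. Here 4-(methylsulfanyl)phenyl replaces 2-phenylethenyl on an aromatic carbon, and the double bond outside aromatic rings leaves with it. Compound 3 therefore carries a 4-substituted phenyl group at the place where compound 1 has 4-ethylphenyl, so the measured step of an at least 3.9-fold lower number from compound 1 to compound 2 (0.59 log units; beyond the scatter) is expected to run largely in reverse. This rests on a single pair of compounds. In this assay the expected change is a 2.4-fold higher number from compound 2 to compound 3 (0.38 log units; beyond the scatter), toward a weaker inhibitor. For compound 3 the estimated value is 60000 nM, with an expected range of 20000 nM to 150000 nM.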

Compound 3, half-maximal inhibitory concentration: 23500 nM
The estimate for compound 3 lay 2.6-fold (0.41 log units) above the measured number, and the stated range covers the measured number.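

In this assay, the exchange on this aromatic carbon gives a 1.1-fold lower number from compound 2 to compound 3 (0.03 log units; within the scatter), so a 4-substituted phenyl group at this place can read the same as 2-phenylethenyl, and across this pair the double bond outside aromatic rings is not required for a measurable number. Among these compounds, the earlier compounds could not show this, since the only 4-substituted phenyl group among them, the 4-ethylphenyl of compound 1, left the reading at a limit; the change of that group's outer substituent alone, methylsulfanyl in place of ethyl, gives an at least 4.2-fold lower number from compound 1 to compound 3 (0.62 log units; beyond the scatter). This places the difference at the far end of the phenyl group and not in the choice between a phenyl and a 2-phenylethenyl group, though the size of the step is a bound and not an exact figure: the limit of > 100000 nM in this assay, at which 1 of the 3 values shown sits.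

The compounds shown leave open whether the sulfur atom of methylsulfanyl matters, which a methoxy group or a longer chain such as propyl at the same place on the phenyl ring would test. They also leave open how an amine or a carboxylic acid there would read, and what happens when the phenylsulfanyl group, common to all three compounds, is replaced.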